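Ring closure of the dipropylamino group on the shared core

This account rests on a few compounds, and the source may have more. Where it says the series, first, only, none or still open, it means among the compounds named here.

Compound 1 `CCCCN(C)c1nc(C(C)(C)C)ccc1CNC(=O)C(C)c1ccc(NS(C)(=O)=O)c(F)c1` gives 1.2 nM in an assay on cells for antagonist activity at transient receptor potential cation channel subfamily V member 1 (Homo sapiens), read by FLIPR and calcium flux, with a stated time of 6 min; on this read-out higher numbers stand for weaker inhibition and lower numbers for stronger inhibition.
Compound 2 `CCCN(CCC)c1nc(C(C)(C)C)ccc1CNC(=O)C(C)c1ccc(NS(C)(=O)=O)c(F)c1` gives 2.5 nM in this assay.

The two measured compounds share one core and differ only in the amino group sitting on an aromatic carbon. Among the compounds with values here, the single measured step between them is a 2.1-fold higher number from compound 1 to compound 2 (0.32 log units; beyond the scatter). Compound 2 therefore stands at the higher of the two numbers, that is the weaker inhibition, and its distance from compound 1 lies just beyond the scatter.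

Compound 3 `CC(C(=O)NCc1ccc(C(C)(C)C)nc1N1CCCC1)c1ccc(NS(C)(=O)=O)c(F)c1` has not been measured. Against compound 2 the change is pyrrolidin-1-yl in place of dipropylamino on an aromatic carbon. Within the data shown here, only one measured step bears on this change, the one from compound 1 to compound 2, and it concerns a different swap on the same aromatic carbon; it shows that changing this amino group moved the number by a modest amount, but it gives no direct guide to a ring in place of two chains. A step of about that size, in either direction, is the most that the data support. Compound 3 is therefore expected to come in near 2 nM, within 0.6 nM to 6 nM, which corresponds to an expected 1.3-fold lower number from compound 2 to compound 3 (0.10 log units; within the scatter).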

Compound 3, inhibition constant: 1.2 nM
Estimate against measurement, compound 3: 1.7-fold (0.22 log units) above; low and high end bracket the measured number.
By their numbers in this assay, from the lowest: compounds 1 and 3 (each within the scatter of the next); then compound 2.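

Closing dipropylamino into pyrrolidin-1-yl gives in this assay a 2.1-fold lower number from compound 2 to compound 3 (0.32 log units; beyond the scatter), so on this aromatic carbon a ring can replace the two chains of compound 2 without any loss, even though the ring is the smaller group by heavy-atom count. Set against the open-chain butyl(methyl)amino group, the same ring gives no change at the digits printed from compound 1 to compound 3 (within the scatter), which means that a chain-bearing amino group and a ring-bearing one can reach the same level here, and that the earlier pair of open-chain compounds gave no sign of this. Nothing measured here accounts for these two steps.

The compounds shown leave open how far ring size can vary at this carbon, for example whether the smaller azetidin-1-yl, the larger piperidin-1-yl or morpholin-4-yl, with its ring oxygen, would stay at this level. Going by these compounds, they also hold the rest of the shared core fixed, so it remains unknown whether the pyrrolidin-1-yl result would carry over if the tert-butyl group gave way to a trifluoromethyl group.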